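Cytotoxicity notes: amide side chain swap toward compound 4

The source may report more compounds than this note shows. Statements on the series, on what has been measured and on what is new or still open speak of the compounds shown alone.

Compound 3 `CN(C)c1cc2[nH]c(C3CCCCC3)nc2cc1NC(=O)c1ccc(C(C)(C)C)cc1` is one of three entries in an ADME assay on Vero cells (Chlorocebus sabaeus) for cytotoxicity, read by resazurin assay, with a stated time of 3 days; on this read-out lower numbers stand for stronger inhibition and higher numbers for weaker inhibition. In this assay compound 3 gives only a limit, > 100 ug/mL. Compound 1 `CCCc1ccc(C(=O)Nc2cc3nc(C4CCCCC4)[nH]c3cc2N(C)C)cc1` also gives only a limit in this assay, > 100 ug/mL. Compound 2 `CCCOCC(=O)Nc1cc2nc(C3CCCCC3)[nH]c2cc1N1CCCC1` likewise gives only a limit in this assay, > 100 ug/mL. Among the measured compounds shown here, the single step between measured compounds, a step that the two limits leave unreadable from compound 1 to compound 3, is unreadable since (the limit of > 100 ug/mL in this assay, at which 3 of the 3 values shown sit). Compound 4 `CCCOCC(=O)Nc1cc2nc(C3CCCCC3)[nH]c2cc1N(C)C` is not yet measured. It differs from compound 3 by propoxymethyl in place of 4-(tert-butyl)phenyl on a carbonyl carbon. For the measured compounds named here, no measured step covers this change: compound 1 and compound 3 differ only in the group on the aromatic carbon, while compound 2 carries the propoxymethyl amide of compound 4 with a different amine. All three measured values sit at the limit, so no step beyond the scatter can be read from them. For compound 4 a value at the limit is expected, so the step that the limit leaves unreadable from compound 3 to compound 4 is estimated to be none beyond the scatter. The estimate for compound 4 is 150 ug/mL, with a range from 60 ug/mL to 400 ug/mL.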

Compound 4, half-maximal inhibitory concentration: < 50 ug/mL
Compound 4 was reported as a limit (the forecaster's own chance of this, stated with the estimate: 85%); middle value at least 3.0-fold (0.47 log units) from the limit.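

In this assay compound 4 gives < 50 ug/mL, a limit of the assay and not a number, and it is the only entry shown with a limit of this sign. On the carbonyl carbon, propoxymethyl in place of 4-(tert-butyl)phenyl gives an at least 2.0-fold lower number from compound 3 to compound 4 (0.30 log units; that floor lies within the scatter), and propoxymethyl in place of 4-propylphenyl gives an at least 2.0-fold lower number from compound 1 to compound 4 (0.30 log units; that floor lies within the scatter). On the aromatic carbon, dimethylamino in place of pyrrolidin-1-yl gives an at least 2.0-fold lower number from compound 2 to compound 4 (0.30 log units; that floor lies within the scatter), so the propoxymethyl amide alone does not set the read-out, though all three steps are only floors within the scatter.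

As far as these compounds go, the true size of these steps stays open, as does whether the lower number needs propoxymethyl and dimethylamino together. Also open, from the compounds shown here alone, is how a longer alkoxy chain or a carboxylic acid on the carbonyl carbon would read with dimethylamino retained.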